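The source may report more compounds than this note shows. Statements on the series, on what has been measured and on what is new or still open speak of the compounds shown alone.

Measured so far in a functional assay on A549 cells (Homo sapiens) for inhibition, read by MTT assay, with a stated time of 72 h; a higher number here means a weaker inhibitor, a lower number a stronger inhibitor:
Compound 1 `O=C(Nc1ccccc1)C1CCN(C/C=C/c2ccccc2)CC1` gives 69700 nM
Compound 2 `COc1ccc(NC(=O)C2CCN(C/C=C/c3ccccc3)CC2)cc1` gives 83800 nM

These two numbers lie within the scatter of each other, so compound 2 holds no rank against compound 1. The next compound is compound 3 `COc1ccccc1NC(=O)C1CCN(C/C=C/c2ccccc2)CC1`, which has the same atoms as compound 2, joined differently: 2-methoxyphenyl in place of 4-methoxyphenyl on an amide-type nitrogen is the whole change, 2-methoxyphenyl in place of 4-methoxyphenyl on an amide-type nitrogen. Going by the values given here, only one measured step bears on it, and only indirectly: a 1.2-fold higher number from compound 1 to compound 2 (0.08 log units; within the scatter) is the step that puts the methoxy in place of hydrogen on an aromatic carbon. Among the compounds with values here, no measured compound carries the 2-methoxyphenyl group. With that single step inside the scatter, no step beyond the scatter is expected in this assay, and no direction can be favoured. The estimate amounts to a 1.1-fold lower number from compound 2 to compound 3 (0.05 log units; within the scatter) as the expected step. For compound 3 the estimated value is 75000 nM (expected range 38000 nM to 150000 nM).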

Compound 3, half-maximal inhibitory concentration: > 100000 nM
Compound 3 gave a limit, no number; the forecaster's own chance of this, stated with the estimate: 15%; middle value at least 1.3-fold (0.12 log units) from the limit.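

What compound 3 gives in this assay is a limit of the assay and not a number: the limit of > 100000 nM in this assay, at which 1 of the 3 values shown sits. With 2-methoxyphenyl in place of 4-methoxyphenyl on an amide-type nitrogen, the result is an at least 1.1-fold higher number from compound 2 to compound 3 (0.07 log units; that floor lies within the scatter), and the methoxy in place of hydrogen on an aromatic carbon gives an at least 1.4-fold higher number from compound 1 to compound 3 (0.15 log units; that floor lies within the scatter). On these data alone, both are floors, so the new compound adds a second methoxy placement, and moving the methoxy brought no measured gain in this assay, though how far the true number lies past either floor stays unknown.

Whether the placement of the methoxy truly matters therefore cannot be settled from these three compounds. Also open, as far as these compounds go, is whether a hydroxy group, a chlorine or an amine in place of the methoxy would give a lower number than the methoxy compounds do.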